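Swapping a Sulfonamide Arm for a Methylphenyl Group

The source may hold more compounds than are shown below. What is called first, only, known or untested is meant among the compounds shown, and "the series" means these compounds.

Compound 1 `O=C1O[C@H]([C@@H](O)Cn2cc(CNS(=O)(=O)c3ccc(F)cc3)nn2)C(OCc2ccccc2)=C1OCc1ccccc1` carries a side arm ending in a sulfonamide. In a functional assay on HepG2 cells (Homo sapiens) for antiproliferative activity, read by MTT assay, with a stated time of 72 h (on this read-out lower numbers stand for stronger inhibition and higher numbers for weaker inhibition), compound 1 gives 18300 nM. That is the only numeric result in this small set. Compound 2 `COc1ccccc1-c1cn(C/C=C2\OC(=O)C(OCc3ccccc3)=C2OCc2ccccc2)nn1`, built on the same core but joined to its five-membered ring through a different linker, reaches only a limit of the measurement: in this assay compound 2 gives > 100000 nM. So compound 1 stands alone as the single measured number, with the other result sitting at the limit of > 100000 nM in this assay, at which 1 of the 2 values shown sits.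

Compound 3 `Cc1ccc(-c2cn(C[C@H](O)[C@H]3OC(=O)C(OCc4ccccc4)=C3OCc3ccccc3)nn2)cc1` differs from compound 1 in one place: 4-methylphenyl in place of (((4-fluorophenyl)sulfonyl)amino)methyl on an aromatic carbon. Among the measured compounds shown here, no step between two measured compounds exists to calibrate this change, so the expectation rests on the weak activity of compound 1 alone. Compound 3 is expected to show a modest loss, with the step from compound 1 to compound 3 estimated as a 1.6-fold higher number from compound 1 to compound 3 (0.21 log units; within the scatter), perhaps within scatter. Compound 3 is therefore estimated at 30000 nM, within 8000 nM to 100000 nM.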

Compound 3, half-maximal inhibitory concentration: 8770 nM
Estimate against measurement, compound 3: 3.4-fold (0.53 log units) above; the range from low to high includes it.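

Placing 4-methylphenyl on the aromatic carbon of the five-membered ring, in place of (((4-fluorophenyl)sulfonyl)amino)methyl, gives a 2.1-fold lower number from compound 1 to compound 3 (0.32 log units; beyond the scatter) in this assay. This position therefore accepts a directly attached aromatic ring, and the sulfonamide arm, with its hydrogen-bond donor and acceptors, is not required for the activity seen here. A single step cannot show which part of this exchange accounts for the difference, and nothing shown explains it.

From the compounds shown here alone, it remains open whether the methyl group contributes at all, or whether an unsubstituted phenyl ring would do as well. Also open, going by these compounds, is how a small aminomethyl group or a carboxylic acid on the phenyl ring would behave at this position.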